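Cytotoxicity notes on the biaryl series: compound 4

The compounds below may be only part of what the source reports. "The series", "measured", "known", "first", "only" and "open" are said of these compounds alone.

The series shares one core and varies only the aryl group placed on the aromatic carbon that sits meta to two methyl groups. Compound 1 `Cc1cc(-c2ccccc2F)cc(C)c1Oc1cc(N)nc(Nc2ccc(C#N)cc2)n1` carries a 2-fluorophenyl there, compound 2 `Cc1cc(-c2cccc(F)c2)cc(C)c1Oc1cc(N)nc(Nc2ccc(C#N)cc2)n1` a 3-fluorophenyl, and compound 3 `Cc1cc(-c2ccccc2Cl)cc(C)c1Oc1cc(N)nc(Nc2ccc(C#N)cc2)n1` a 2-chlorophenyl. In a toxicity assay on MT4 cells (Homo sapiens) for cytotoxicity, read by MTT assay (a higher number here means that more compound is tolerated, a lower number that less compound is tolerated), compound 1 gives 29300 nM, compound 2 gives 24700 nM and compound 3 gives 25100 nM. Compound 2 holds the lowest of the three numbers, but every gap is within the scatter: a 1.2-fold lower number from compound 1 to compound 2 (0.07 log units; within the scatter), a 1.0-fold higher number from compound 2 to compound 3 (0.01 log units; within the scatter) and a 1.2-fold lower number from compound 1 to compound 3 (0.07 log units; within the scatter). Nothing in these three values separates one aryl group from another in this assay.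

Compound 4 `Cc1cc(-c2ccccc2C#N)cc(C)c1Oc1cc(N)nc(Nc2ccc(C#N)cc2)n1` is the unmeasured member. Relative to compound 2 the change is 2-cyanophenyl in place of 3-fluorophenyl on an aromatic carbon. Among the measured compounds shown here, no measured step exchanges a halogen for a cyano group, so the nearest guides are the moves between the 2-fluorophenyl, 3-fluorophenyl and 2-chlorophenyl members, all of which stayed within the scatter. On that basis no step beyond the scatter is expected in this assay, so compound 4 is expected to give 25000 nM, within 12000 nM to 50000 nM, which would mean an estimated step of a 1.0-fold higher number from compound 2 to compound 4 (0.01 log units; within the scatter).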

Compound 4, half-maximal cytotoxic concentration: 25400 nM
For compound 4 the middle estimate is 1.0-fold (0.01 log units) below the measured one; the measured number falls inside the stated range.
By their numbers in this assay, from the lowest: compounds 2, 3, 4 and 1 (each within the scatter of the next).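

Among the compounds shown here, compound 4 brings the first group on this aromatic carbon, meta to two methyl groups, that is not halogen-substituted, and the change still leaves the number in this assay unmoved beyond the scatter: a 1.0-fold higher number from compound 2 to compound 4 (0.01 log units; within the scatter), a 1.0-fold higher number from compound 3 to compound 4 (0.01 log units; within the scatter) and a 1.2-fold lower number from compound 1 to compound 4 (0.06 log units; within the scatter). The insensitivity seen among the 2-fluorophenyl, 3-fluorophenyl and 2-chlorophenyl members therefore extends to a 2-cyanophenyl, which adds a triple bond outside the aromatic ring and a hydrogen-bond acceptor that 3-fluorophenyl lacks. No available evidence bears on the cause of this lack of separation.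

The compounds shown leave open whether the same holds when the aryl group carries a primary amine or a carboxylic acid, the latter bringing a net charge that none of the four groups here has. They also leave open whether moving the nitrile, as in a 3-cyanophenyl or 4-cyanophenyl, or replacing the phenyl ring with a longer alkyl chain would keep this assay within the scatter of these four compounds.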